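From a pyridine to a propyl chain on the amide nitrogen

This account rests on a few compounds, and the source may have more. Where it says the series, first, only, none or still open, it means among the compounds named here.

Of the compounds shown here, three sharing one core have been measured in an assay on HEK293 cells for agonist activity at transient receptor potential cation channel subfamily M member 8 (Homo sapiens), read by fluorescence and calcium flux, with a stated time of 15 min; a higher number here means that more compound is needed for the effect, a lower number that less compound is needed. Compound 1 `CCN(Cc1cccs1)C(=O)COc1ccc(F)cc1` gives 422 nM, compound 2 `Cc1ccc(OCC(=O)N(Cc2cccs2)c2c(C)n[nH]c2C)cc1` gives 0.3 nM, and compound 3 `Cc1ccc(OCC(=O)N(Cc2cccs2)c2ccncc2)cc1` gives 52 nM. Compound 3 thus stands second highest of the three, with compound 1 closest to it and compound 2 far below it. Among the measured compounds shown here, the only step between two measured compounds that differ in a single place is a 170-fold higher number from compound 2 to compound 3 (2.24 log units; beyond the scatter), a large loss when a ring with one hetero atom replaces the dimethylpyrazole on the amide-type nitrogen.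

Compound 4 `CCCN(Cc1cccs1)C(=O)COc1ccc(C)cc1` is not yet measured. It differs from compound 3 as follows: propyl in place of pyridin-4-yl on an amide-type nitrogen. For the measured compounds named here, no measured pair shows this exact change, but compound 1, which also carries a short chain on that nitrogen, gives 422 nM in this assay, a higher number than compound 3. Compound 4 is therefore expected to sit near compound 1, at an estimated 400 nM with a range of 100 nM to 1600 nM, and the expected step is a 7.7-fold higher number from compound 3 to compound 4 (0.89 log units; beyond the scatter).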

Compound 4, half-maximal effective concentration: 40 nM
Beside the measured number, compound 4's estimate is 10-fold (1.00 log units) above it, and the stated range ends above it.
By their numbers in this assay, from the lowest: compound 2; then compounds 4 and 3 (each within the scatter of the next); then compound 1.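

In this assay, propyl in place of pyridin-4-yl on the amide-type nitrogen gives a 1.3-fold lower number from compound 3 to compound 4 (0.11 log units; within the scatter) and so shows that, in this series, an aromatic ring at this position is not needed to match the number of compound 3. Propyl in place of 3,5-dimethyl-1H-pyrazol-4-yl gives a 130-fold higher number from compound 2 to compound 4 (2.12 log units; beyond the scatter) and, read with a 170-fold higher number from compound 2 to compound 3 (2.24 log units; beyond the scatter) as the second large step, sets the dimethylpyrazole of compound 2 apart from both other groups at this position. No evidence here explains why the dimethylpyrazole stands apart. As far as these compounds go, whether a pyrazole without its two methyl groups would keep the low number of compound 2 remains open. Also open, from the compounds shown here alone, is how a longer chain such as butyl, or an amine at the end of the propyl chain, would compare with compound 4 in this assay.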